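This account rests on a few compounds, and the source may have more. Where it says the series, first, only, none or still open, it means among the compounds named here.

Of the compounds shown here, three of a shared core have so far been tested in a functional assay on MGC-803 cells (Homo sapiens) for antiproliferative activity, read by MTT assay, with a stated time of 72 h; on this read-out lower numbers stand for stronger inhibition and higher numbers for weaker inhibition. Compound 1 `CCCSc1nc(N/N=C/c2cccnc2)c2nnn(Cc3ccccc3)c2n1` gives 38100 nM, the highest number among the three. Compound 2 `C#CCSc1nc(N/N=C/c2ccc(N(C)C)cc2)c2nnn(Cc3ccccc3)c2n1` gives 7620 nM, and compound 3 `CCCSc1nc(N/N=C(\C)c2ccccc2O)c2nnn(Cc3ccc(F)cc3)c2n1` gives 11000 nM; both of these lie beyond the scatter from compound 1, with compound 3 the nearest to it and compound 2 the furthest.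

Compound 4 `CCCSc1nc(N/N=C/c2ccccc2)c2nnn(Cc3ccccc3)c2n1` has not yet been measured. It differs from compound 1 in a single place: phenyl in place of pyridin-3-yl on a carbon with a double bond to nitrogen. Within the data shown here, no pair of measured compounds shows this change, so there is no observed step on which to rest a firm direction. Nothing in the three measured compounds points to a large shift for this exchange, so the step is expected to be small, either way, and most likely no larger than the scatter.

The step from compound 1 to compound 4 is therefore expected to be about a 1.2-fold lower number from compound 1 to compound 4 (0.08 log units; within the scatter). Compound 4 is estimated at 32000 nM, within a range from 11000 nM to 95000 nM.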

Compound 4, half-maximal inhibitory concentration: > 64000 nM
Compound 4 was reported as a limit; the forecaster's own chance of this, stated with the estimate: 10%; middle value at least 2.0-fold (0.30 log units) away from the limit.
By their numbers in this assay, from the lowest: compounds 2 and 3 (each within the scatter of the next); then compound 1. At a limit, above all of these: compound 4.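

In this assay compound 4 is reported only as a limit, > 64000 nM, and not as an exact number. Exchanging pyridin-3-yl for phenyl on this carbon keeps a six-membered aromatic ring but removes the ring nitrogen and its hydrogen-bond acceptor, and it gives an at least 1.6-fold higher number from compound 1 to compound 4 (0.22 log units; that floor lies within the scatter), so this exchange brings no sign of stronger inhibition, though the floor alone does not establish a real loss. The true size of the step cannot be read from this result, and the measurement stops at a limit: the limit of > 64000 nM in this assay, at which 1 of the 4 values shown sits.

Going by these compounds, it remains open whether other rings at this place, such as pyridin-4-yl or a phenyl bearing a carboxylic acid, would lower the number. On these data alone, whether the same exchange would behave alike on a different side chain, such as a longer chain in place of the propyl chain, also remains unknown.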